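Swapping Chloro for Trifluoromethyl on Two Related Cores

The source may hold more compounds than are shown below. What is called first, only, known or untested is meant among the compounds shown, and "the series" means these compounds.

The measured compounds, all tested in an assay on Sf9 cells for inhibition of inhibitor of nuclear factor kappa-B kinase subunit epsilon (Homo sapiens), read by ADP-Glo, with a stated time of 60 min; a higher number here means a weaker inhibitor, a lower number a stronger inhibitor:
compound 1, `Cc1[nH]nc(N)c1-c1cccc(Cl)c1`, gives 93400 nM
compound 2, `Cc1[nH]nc(N)c1-c1cccc(C(F)(F)F)c1`, gives > 100000 nM, which is a limit of the assay
compound 3, `CC(=O)n1nc(C)c(-c2cccc(Cl)c2)c1N`, gives > 100000 nM, which is a limit of the assay

Only compound 1 yields a number; the other two reach (the limit of > 100000 nM in this assay, at which 2 of the 3 values shown sit). The change from compound 1 to compound 2 is trifluoromethyl in place of chloro on an aromatic carbon. That change made an at least 1.0-fold higher number from compound 1 to compound 2 (0.02 log units; that floor lies within the scatter). The true size of this step is not known, since compound 2 sits at the limit of > 100000 nM in this assay, at which 2 of the 3 values shown sit.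

Compound 3 is built on a different core from compound 1; how the two cores differ is not broken down here. Compound 4, `CC(=O)n1nc(C)c(-c2cccc(C(F)(F)F)c2)c1N`, is not yet measured. The change from compound 3 to compound 4 is trifluoromethyl in place of chloro on an aromatic carbon. Among the compounds with values here, this is the same kind of change as the one from compound 1 to compound 2, though the surroundings are described differently: in the first case the place is "meta to a group of 7 heavy atoms", in the second "meta to a large group".

Compound 3 already stands at the limit of > 100000 nM in this assay, at which 2 of the 3 values shown sit, and the earlier instance of this change produced an at least 1.0-fold higher number from compound 1 to compound 2 (0.02 log units; that floor lies within the scatter). The expected step is therefore a step that the limit leaves unreadable from compound 3 to compound 4, a move that stays at or beyond the limit. Compound 4 is estimated at 150000 nM, most likely reported as a limit, with a range of 100000 nM to 400000 nM.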

Compound 4, half-maximal inhibitory concentration: > 100000 nM
Compound 4: no number, only a limit; the forecaster's own chance of this, stated with the estimate: 90%; the middle value is on the limit's open side.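

In this assay compound 4 gives > 100000 nM which is a limit of the assay. Within the data shown here, compound 3 sits at the same kind of limit, so no step from compound 3 to compound 4 can be read: the limit of > 100000 nM in this assay, at which 3 of the 4 values shown sit. Left open is how far trifluoromethyl in place of chloro shifts inhibition on either core, and how weak compound 2, compound 3 and compound 4 truly are.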